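From 4-chlorophenyl to 2-chlorophenyl on a shared core

The source may report more compounds than this note shows. Statements on the series, on what has been measured and on what is new or still open speak of the compounds shown alone.

Compound 1 `C=CC(=O)N1C(=O)CC(c2ccc(OC)cc2)Sc2ccccc21` gives 32900 nM
Compound 2 `C=CC(=O)N1C(=O)CC(c2ccc(Br)cc2)Sc2ccccc21` gives 59400 nM
Compound 3 `C=CC(=O)N1C(=O)CC(c2ccc(Cl)cc2)Sc2ccccc21` gives 22600 nM

All three values come from a functional assay on NB-4 cells (Homo sapiens) for cytotoxicity, read by CCK-8 assay, with a stated time of 24 h (on this read-out lower numbers stand for stronger inhibition and higher numbers for weaker inhibition), and the compounds share one core, carrying methoxy, bromo or chloro in turn. Compound 3 gives 22600 nM here and cannot be told apart from the methoxy compound: the change is a 1.5-fold lower number from compound 1 to compound 3 (0.16 log units; within the scatter) and no more. Among the compounds with values here, it does stand apart from the bromo compound, with a 2.6-fold lower number from compound 2 to compound 3 (0.42 log units; beyond the scatter) as the only one of the three steps that clears the scatter, while a 1.8-fold higher number from compound 1 to compound 2 (0.26 log units; within the scatter) stays inside it.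

Compound 4 `C=CC(=O)N1C(=O)CC(c2ccccc2Cl)Sc2ccccc21` has the same atoms as compound 3, joined differently: 2-chlorophenyl in place of 4-chlorophenyl on a saturated ring carbon. Within the data shown here, none of the measured steps moves a group to a new place. Each swaps one group for another, so they bear on this change only indirectly, by showing how far the numbers moved among these three compounds. They give no direction, and a step beyond the scatter is not expected in this assay for this change. The estimated step is a 1.1-fold higher number from compound 3 to compound 4 (0.04 log units; within the scatter), which amounts to little expected change. For compound 4 the estimate is 25000 nM as a middle value, with 10000 nM to 60000 nM as the expected range.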

Compound 4, half-maximal inhibitory concentration: 33800 nM
Beside the measured number, compound 4's estimate is 1.4-fold (0.13 log units) below it, within the range that was stated.
By their numbers in this assay, from the lowest: compounds 3, 1, 4 and 2 (each within the scatter of the next, the first and the last beyond it).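

In this assay, within the data shown here, putting 2-chlorophenyl in place of 4-chlorophenyl on the saturated ring carbon next to the ring sulfur gives a 1.5-fold higher number from compound 3 to compound 4 (0.17 log units; within the scatter), the first step here that moves a group rather than swapping it, and the two compounds cannot be told apart. Compound 4 is equally hard to separate from the other two compounds, with a 1.8-fold lower number from compound 2 to compound 4 (0.24 log units; within the scatter) and a 1.0-fold higher number from compound 1 to compound 4 (0.01 log units; within the scatter), so a 2.6-fold lower number from compound 2 to compound 3 (0.42 log units; beyond the scatter) remains the only step among these four compounds that clears the scatter. Nothing available explains why these numbers fall as they do.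

Going by these compounds, it remains open whether an amine or a carboxylic acid on the phenyl ring, or a longer chain in place of that ring, would give a step beyond the scatter from compound 3. On these data alone, it is also open whether the close match between compound 3 and compound 4 would hold in a read-out other than this assay.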